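The compounds below may be only part of what the source reports. "The series", "measured", "known", "first", "only" and "open" are said of these compounds alone.

Of the compounds shown here, two have so far been tested in a functional assay on the whole organism (Abdomen, strain Swiss albino) with Mus musculus as the target, with stated times of 10 min and 5 min, at a dose of 30 mg/kg by the oral route; a higher number here means a stronger effect of the compound at the dose given, a lower number a weaker effect. Compound 1 has the structure `CCOc1ccc(-c2nn(-c3ccccc3)cc2C2=NOC3C(=O)N(c4ccccc4)C(=O)C23)cc1` and in this assay compound 1 gives 49.5%. Compound 2 has the structure `CCOC(=O)c1onc(-c2cn(-c3ccccc3)nc2-c2ccc(Br)cc2)c1C(=O)OCC` and in this assay compound 2 gives 56.9%. The two numbers lie within the usual scatter of such measurements, so compound 2 and compound 1 cannot be told apart on what is known; neither can be called the more active of the pair.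

Compound 3, with the structure `CCOC(=O)c1onc(-c2cn(-c3ccccc3)nc2-c2ccc(OC)cc2)c1C(=O)OCC`, has not been measured. It differs from compound 2 at one place: methoxy in place of bromo on an aromatic carbon. Within the data shown here, nothing among the measured compounds changes only this one group, so there is no earlier step to lean on.

With so little to go by, the step from compound 2 to compound 3 is expected to be small and is likely to fall within the scatter; its direction is open, and the expected step is a number 6.9 percentage points lower from compound 2 to compound 3 (within the scatter). Compound 3 is therefore estimated to give about 50% in this assay, with a range from 30% to 70%.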

Compound 3, a percentage reported as activity, at one dose (the size of the read-out at that dose, not a potency): 57.7%
For compound 3 the middle estimate is 7.7 percentage points below the measured one; low and high end bracket the measured number.
By their numbers in this assay, from the lowest: compounds 1, 2 and 3 (each within the scatter of the next).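

In this assay, putting methoxy in place of bromo on the aromatic carbon para to a large group gives a step of a number 0.8 percentage points higher from compound 2 to compound 3 (within the scatter) and so leaves the 4-bromophenyl and 4-methoxyphenyl versions indistinguishable at this dose. Among these compounds, this is the first pair that changes in only one place, so it offers the first direct reading at this position: a single bromine atom can be exchanged for a group with two heavy atoms and one hydrogen-bond acceptor without any readable change in the effect. No supporting measurement is available to explain why these two groups read alike.

Two groups at one position, tested at one dose, say little about how far this tolerance extends, and an amine, a carboxylic acid or a longer chain such as butoxy on the same aromatic carbon could still read quite differently. As far as these compounds go, it also remains open whether the same exchange would read alike on the core of compound 1, or whether a difference between compound 2 and compound 3 would appear at other doses.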